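Adding a Methylbenzyl Group to the Ring Nitrogen of Compound 1

This account rests on a few compounds, and the source may have more. Where it says the series, first, only, none or still open, it means among the compounds named here.

Compound 1 `O=C1Nc2ccc(Cl)cc2/C1=N/NC(=S)Nc1ccc(Cl)cc1` was tested in a functional assay on CCRF-CEM cells (Homo sapiens), with a stated time of 72 h (on this read-out lower numbers stand for stronger inhibition and higher numbers for weaker inhibition), where compound 1 gives 61000 nM. Compound 2 `O=C1Nc2ccc(Br)cc2/C1=N/NC(=S)Nc1ccc(Cl)cc1`, which carries bromo in place of chloro on an aromatic carbon, gives 61000 nM, and the step of no change at the digits printed from compound 1 to compound 2 (within the scatter). Compound 3 `O=C1Nc2ccc(F)cc2/C1=N/NC(=S)Nc1ccc(Cl)cc1`, which carries fluoro in place of chloro on an aromatic carbon, gives 25000 nM; the step of a 2.4-fold lower number from compound 1 to compound 3 (0.39 log units; beyond the scatter), and the step of a 2.4-fold lower number from compound 2 to compound 3 (0.39 log units; beyond the scatter). Compound 1 thus stands level with compound 2, the two together being the highest of the three numbers, with compound 3 the only one set apart from them.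

Compound 4 `Cc1ccc(CN2C(=O)/C(=N\NC(=S)Nc3ccc(Cl)cc3)c3cc(Cl)ccc32)cc1` differs from compound 1 in a single place: 4-methylbenzyl in place of hydrogen on an amide-type nitrogen in a ring. All three measured steps exchange one halogen for another on an aromatic carbon; none of them touches the ring nitrogen, so none bears directly on this change. For the measured compounds named here, they show only that the shared core moves by modest amounts when one halogen is swapped for another. With no direct guide, the expected step of a 2.0-fold lower number from compound 1 to compound 4 (0.31 log units; beyond the scatter) is modest and uncertain in direction. Compound 4 is therefore estimated to give 30000 nM in this assay, expected to fall between 5000 nM and 150000 nM.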

Compound 4, half-maximal inhibitory concentration: 18000 nM
The estimate for compound 4 lay 1.7-fold (0.22 log units) above the measured number; the measured number falls inside the stated range.
By their numbers in this assay, from the lowest: compounds 4 and 3 (each within the scatter of the next); then compounds 1 and 2 (each within the scatter of the next).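

In this assay, putting 4-methylbenzyl on the amide-type nitrogen in the ring, where compound 1 carries the amide hydrogen, gives a 3.4-fold lower number from compound 1 to compound 4 (0.53 log units; beyond the scatter). For the compounds shown here, the earlier steps only exchanged one halogen for another on an aromatic carbon, so this is the first view of the ring nitrogen: its hydrogen is not required for inhibition in these cells, and a group with a six-membered aromatic ring can sit there with a modest gain rather than a loss. Nothing in the data shown explains this gain, so it stands as an observation without a known cause.

This single step cannot say whether the gain belongs to the aromatic ring, to the methyl on it, or to any group at all on this nitrogen; a plain methyl, an unsubstituted benzyl, or a longer chain ending in an amine or a carboxylic acid would help to separate these possibilities. On these data alone, it also remains open whether 4-methylbenzyl on this nitrogen would change the number by a similar amount with bromo or fluoro in place of the chloro on the shared core.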